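Chloro to bromo on the aryl triazole of the sulfonate

The compounds below may be only part of what the source reports. "The series", "measured", "known", "first", "only" and "open" are said of these compounds alone.

Three members of the series have been measured in a functional assay on A549 cells (Homo sapiens) for cytotoxicity, read by MTT assay, with a stated time of 4 days; on this read-out higher numbers stand for weaker inhibition and lower numbers for stronger inhibition. Compound 1 `Cc1c(O)ccc2c1[C@H](Cn1cc(-c3ccc(Cl)cc3)nn1)[C@@]13CC(=O)[C@@](C)(CC[C@@H]21)C3` reaches only a limit of the assay, > 20000 nM. Compound 2 `Cc1ccc(S(=O)(=O)Oc2ccc3c(c2C)[C@H](Cn2cc(-c4ccc(Cl)cc4)nn2)[C@@]24CC(=O)[C@@](C)(CC[C@@H]32)C4)cc1` likewise gives only a limit, > 20000 nM. Compound 3 `C=C1C[C@]23C[C@@]1(O)CC[C@H]2c1cc(Br)c(O)c(C)c1[C@@H]3Cn1cc(-c2ccc(OC)cc2)nn1` also stops at a limit, > 20000 nM. Going by the values given here, the single one-place step in the set, a step that the two limits leave unreadable from compound 1 to compound 2, is therefore of unreadable size. Where compound 2 stands is summarised by the limit of > 20000 nM in this assay, at which 3 of the 3 values shown sit: it carries no numbered value in this assay, only the shared limit.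

Compound 4 `Cc1ccc(S(=O)(=O)Oc2ccc3c(c2C)[C@H](Cn2cc(-c4ccc(Br)cc4)nn2)[C@@]24CC(=O)[C@@](C)(CC[C@@H]32)C4)cc1` differs from compound 2 by bromo in place of chloro on an aromatic carbon. Among the compounds with values here, no measured step concerns this position; the one step that exists sits elsewhere and its size cannot be read, so nothing in the data points to a direction for the change. The expectation is thus carried by the limit of > 20000 nM in this assay, at which 3 of the 3 values shown sit, alone. Compound 4 is expected, on that basis, to come out in this assay at about 25000 nM, most likely again as a limit rather than a number, with a range from 5000 nM to 100000 nM. The step that the limit leaves unreadable from compound 2 to compound 4 is accordingly expected to be nothing beyond the scatter, if it can be read at all.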

Compound 4, half-maximal inhibitory concentration: > 20000 nM
Compound 4 gave a limit, no number; the forecaster's own chance of this, stated with the estimate: 85%; the middle value is on the limit's open side.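

In this assay compound 4 gives > 20000 nM, a limit and not a number. Compound 2 also stands at a limit, so the chloro to bromo step between compound 2 and compound 4 cannot be read. All compounds shown sit together: the limit of > 20000 nM in this assay, at which 4 of the 4 values shown sit. On these data alone, whether any change to these structures gives a numbered value in this assay remains open.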